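The source may report more compounds than this note shows. Statements on the series, on what has been measured and on what is new or still open speak of the compounds shown alone.

Measured so far in an ADME assay on HEK293 cells (Homo sapiens) for cytotoxicity, read by resazurin assay, with a stated time of 48 h; a lower number here means that less compound is tolerated, a higher number that more compound is tolerated:

compound 1 `COc1ccc(S(=O)(=O)Nc2ccc3oc(-c4ccccc4)nc3c2)cc1` gives 91000 nM
compound 2 `O=S(=O)(Nc1ccc2oc(-c3ccccc3)nc2c1)c1ccc(C(F)(F)F)cc1` gives 74000 nM
compound 3 `O=S(=O)(Nc1ccc(-c2nc3ccccc3o2)cc1)c1ccc(C(F)(F)F)cc1` gives 94000 nM

Compound 1 and compound 2 share one core; compound 3 carries the other. The difference between the two cores is not broken down here, and the values of compound 2 and compound 3 lie within the scatter of each other. On the core of compound 2, the change methoxy in place of trifluoromethyl on an aromatic carbon gave a 1.2-fold higher number from compound 2 to compound 1 (0.09 log units; within the scatter). Compound 4 `COc1ccc(S(=O)(=O)Nc2ccc(-c3nc4ccccc4o3)cc2)cc1` is not yet measured; it is made from compound 3 by methoxy in place of trifluoromethyl on an aromatic carbon, the same change on the other core. Going by the values given here, since that change left the number within the scatter once, a step of about a 1.1-fold higher number from compound 3 to compound 4 (0.05 log units; within the scatter) is expected here as well, resting on the one earlier step of a 1.2-fold higher number from compound 2 to compound 1 (0.09 log units; within the scatter) and on compound 3 at 94000 nM. Compound 4 is therefore estimated at 105000 nM, between 55000 nM and 200000 nM.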

Compound 4, half-maximal cytotoxic concentration: > 100000 nM
Compound 4: no number, only a limit (the forecaster's own chance of this, stated with the estimate: 30%); the middle value does not contradict the limit.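

In this assay compound 4 gives > 100000 nM, which is a limit of the assay and not a number. Methoxy in place of trifluoromethyl on an aromatic carbon gives an at least 1.0-fold higher number from compound 3 to compound 4 (0.02 log units; that floor lies within the scatter), so on the core of compound 3 the change has only a floor, and the two steps can be set side by side only as far as that floor allows: the same change on two cores in this assay, a 1.2-fold higher number (0.09 log units; within the scatter) from compound 2 to compound 1 and an at least 1.0-fold higher number (0.02 log units; that floor lies within the scatter) from compound 3 to compound 4; the limit leaves it open whether they differ The result therefore does not show that the step carries over from one core to the other with the same size, nor that it does not.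

The compounds shown leave open how either core responds to a different group in that place, such as an amine or a carboxylic acid. They also leave open whether any such group would bring the number down beyond the scatter.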